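The source may report more compounds than this note shows. Statements on the series, on what has been measured and on what is new or still open speak of the compounds shown alone.

Working notes on the series. For the measured compounds named here, compound 1 `C=CCn1c(=O)/c(=C\c2cccc(C)c2)[nH]c(=O)/c1=C\c1ccccc1OC` is, in a functional assay on K562 cells (Homo sapiens) for cytotoxicity, read by CCK-8 assay, with a stated time of 72 h (on this read-out higher numbers stand for weaker inhibition and lower numbers for stronger inhibition), the only member with a number: compound 1 gives 8800 nM. Compound 2 `C=CCn1c(=O)/c(=C\c2ccc(Cl)c(Cl)c2)[nH]c(=O)/c1=C\c1ccccc1` is reported in this assay only as "not active" (no number reported), with no number. Compound 3 `C=CCn1c(=O)/c(=C\c2ccc(C)cc2)[nH]c(=O)/c1=C\c1ccccc1OC` is not yet measured; it differs from compound 1 by 4-methylphenyl in place of 3-methylphenyl on a double-bonded chain carbon bound to an aromatic carbon. Going by the values given here, no pair of measured compounds shows a step of this kind, so the size of the change cannot be read from the data; the step from compound 1 to compound 3 in this assay is expected to stay within the scatter, a 1.0-fold higher number from compound 1 to compound 3 (0.01 log units; within the scatter). For compound 3 in this assay the estimate is 9000 nM, between 4000 nM and 20000 nM.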

Compound 3, half-maximal inhibitory concentration: "not active" (no number reported)
The entry for compound 3 holds no number, and the estimate cannot be compared.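

In this assay, for the compounds shown here, compound 3 carries no number, so no step from compound 1 to compound 3 can be read. The compounds shown leave open what size of change 4-methylphenyl in place of 3-methylphenyl brings. No measured evidence bears on this result.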